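A few compounds are considered here, and "the series" means these few. Any claim that something is new, unique, unknown or untested is made for them only; others in the source may bear on it.

The three measured compounds and their values in an assay on HEK293 cells for inhibition of Steryl-sulfatase (Homo sapiens), tested at 0.1 uM; on this read-out lower numbers stand for a weaker effect and higher numbers for a stronger effect at the one concentration tested:
compound 1, `CCN(Cc1cccnc1)c1ccc(C(=O)N2CCc3ccc(OS(N)(=O)=O)cc3C2)cc1`, 35.7%;
compound 2, `CN(C)CCCN(Cc1ccccc1)c1ccc(C(=O)N2CCc3ccc(OS(N)(=O)=O)cc3C2)cc1`, 16.2%;
compound 3, `CCCN(Cc1ccccc1)c1ccc(C(=O)N2CCc3ccc(OS(N)(=O)=O)cc3C2)cc1`, 64.8%.

Compound 3 stands highest of the three numbers: the step of a number 29.1 percentage points higher from compound 1 to compound 3 (beyond the scatter) and the step of a number 48.6 percentage points higher from compound 2 to compound 3 (beyond the scatter) both lead up to it, and both lie beyond the scatter.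

Compound 4, `CN(C)CCN(Cc1ccccc1)c1ccc(C(=O)N2CCc3ccc(OS(N)(=O)=O)cc3C2)cc1`, has not been measured. It differs from compound 3 in one place: dimethylamino in place of methyl on a saturated chain carbon, two bonds along the chain from a nitrogen on an aromatic ring. Put another way, the propyl of compound 3 becomes 2-(dimethylamino)ethyl in compound 4.

Going by the values given here, the step that bears most directly on this is the one between compound 2 and compound 3, since it concerns the same dimethylamino group, one bond further along the same kind of chain: a number 48.6 percentage points higher from compound 2 to compound 3 (beyond the scatter), a large step. Going from compound 3 to compound 4 brings such a dimethylamino group back, now two bonds along. The step of a number 29.1 percentage points higher from compound 1 to compound 3 (beyond the scatter) changes a different part of the molecule and is less informative here. A large drop is therefore expected, estimated as a number 44.8 percentage points lower from compound 3 to compound 4 (beyond the scatter). Compound 4 is expected to give about 20% in this assay, in the range 5% to 45%.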

Compound 4, a percentage reported as inhibition, at one concentration (the size of the read-out at that concentration, not a potency): 13.9%
The estimate for compound 4 lay 6.1 percentage points above the measured number; the measured number falls inside the stated range.
By their numbers in this assay, from the lowest: compounds 4 and 2 (each within the scatter of the next); then compound 1; then compound 3.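

In this assay, swapping methyl for dimethylamino on a saturated chain carbon, two bonds along the chain from a nitrogen on an aromatic ring, gives a number 50.9 percentage points lower from compound 3 to compound 4 (beyond the scatter), so the low number seen with dimethylamino three bonds along the chain also appears at this place. The two places are not told apart by this read-out, with a number 2.3 percentage points lower from compound 2 to compound 4 (within the scatter), which means that in these two compounds the position of the group along the chain does not visibly matter. No measurement at hand explains why the dimethylamino group goes with these low numbers.

On these data alone, it stays open whether a methoxy or hydroxyl group on the same chain carbon would lower the number as far as dimethylamino does. As far as these compounds go, it also stays open whether a primary amine there would behave like dimethylamino or more like the plain propyl chain.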